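Ethylcarbamoyl for pyridin-3-yl on a sulfonamide-linked pyridine

The compounds below may be only part of what the source reports. "The series", "measured", "known", "first", "only" and "open" are said of these compounds alone.

Measured compounds:
compound 1 `COc1ccc(Cl)cc1S(=O)(=O)Nc1cncc(-c2cccnc2)c1`, 73 nM
compound 2 `CNC(=O)c1cncc(NS(=O)(=O)c2cc(Cl)ccc2OC)c1`, 109 nM
compound 3 `COc1ccc(S(=O)(=O)Nc2cccnc2)c(OC)c1`, 10300 nM

In an assay on isolated protein for inhibition of alkaline phosphatase, tissue-nonspecific isozyme (Homo sapiens) (a higher number here means a weaker inhibitor, a lower number a stronger inhibitor), compound 1 gives the lowest of the three numbers. Its nearest neighbour is compound 2, and the step of a 1.5-fold higher number from compound 1 to compound 2 (0.17 log units; within the scatter) lies within the scatter, so no order between the two can be claimed. Compound 3, with 10300 nM, stands far higher than compound 1.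

Compound 4 `CCNC(=O)c1cncc(NS(=O)(=O)c2cc(Cl)ccc2OC)c1` has not yet been measured. It differs from compound 1 in one place: ethylcarbamoyl in place of pyridin-3-yl on an aromatic carbon. Among the compounds with values here, the one measured step that bears on this change is a 1.5-fold higher number from compound 1 to compound 2 (0.17 log units; within the scatter), where a methylcarbamoyl group took the same place and the number barely moved. Lengthening the chain by one carbon to ethylcarbamoyl is a smaller change than the exchange of ring for carboxamide already seen, so in this assay no step beyond the scatter is expected for compound 4, and the estimate is a 1.6-fold higher number from compound 1 to compound 4 (0.22 log units; within the scatter). Compound 4 is therefore estimated at 120 nM, with a range from 50 nM to 300 nM.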

Compound 4, half-maximal inhibitory concentration: 193 nM
Estimate against measurement, compound 4: 1.6-fold (0.21 log units) below, within the range that was stated.
By their numbers in this assay, from the lowest: compounds 1, 2 and 4 (each within the scatter of the next, the first and the last beyond it); then compound 3.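

In this assay the ethylcarbamoyl group, placed two atoms from the ring nitrogen, gives the first replacement of pyridin-3-yl by an open-chain amide whose step passes the scatter: the result is a 2.6-fold higher number from compound 1 to compound 4 (0.42 log units; beyond the scatter) and that step is modest. The extra methyl on the chain carbon bound to the amide nitrogen does not separate the two amides, as the pair shows a 1.8-fold higher number from compound 2 to compound 4 (0.25 log units; within the scatter) and so compound 2 and compound 4 cannot be ordered. Nothing at hand explains why the ethylcarbamoyl step passes the scatter while the methylcarbamoyl step does not.

The compounds shown leave open whether a longer chain such as propyl on the amide nitrogen would stay near these numbers or move away from them. They also leave open how a carboxylic acid, an unsubstituted carboxamide or an amine would read at this place.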